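A few compounds are considered here, and "the series" means these few. Any claim that something is new, unique, unknown or untested is made for them only; others in the source may bear on it.

For the measured compounds named here, compound 2, with the structure `COC(=O)c1cccc(CSc2nc3ccccc3n2CC(=O)O)c1`, is one of two compounds measured in an assay on HEK293 cells for displacement of a labelled ligand from prostaglandin D2 receptor 2 (Homo sapiens); on this read-out higher numbers stand for weaker inhibition and lower numbers for stronger inhibition. There compound 2 gives 450 nM, the higher of the two numbers. The other compound, compound 1, has the structure `O=C(O)Cn1c(SCc2ccc(Br)cc2)nc2ccccc21` and gives 220 nM in this assay; the gap between these two values lies beyond the usual scatter, and the two structures differ in more than one place, so no single change can be read from them.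

Compound 3, with the structure `COC(=O)c1cc(CSc2nc3ccccc3n2CC(=O)O)ccc1Br`, has not been measured. It differs from compound 2 by bromo in place of hydrogen on an aromatic carbon. Compound 1 also carries a bromo group on its benzylic ring and gives the lower of the two numbers in this assay, but it lacks the methoxycarbonyl group, so the two cases are not directly comparable. For compound 3 a small step toward a lower number in this assay is expected, of a size that may not reach beyond the scatter; the step from compound 2 to compound 3 is estimated at a 1.6-fold lower number from compound 2 to compound 3 (0.21 log units; within the scatter). Compound 3 is therefore expected to give about 280 nM in this assay, in a range from 110 nM to 700 nM.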

Compound 3, half-maximal inhibitory concentration: 980 nM
For compound 3 the middle estimate is 3.5-fold (0.54 log units) below the measured one; the whole stated range lies below it.
By their numbers in this assay, from the lowest: compound 1; then compound 2; then compound 3.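

In this assay, bromo on the aromatic carbon that is ortho to a methoxycarbonyl group and para to a large group gives a 2.2-fold higher number from compound 2 to compound 3 (0.34 log units; beyond the scatter) and so goes with weaker inhibition on this ring. Adding a methoxycarbonyl group to the bromo-bearing ring gives a 4.5-fold higher number from compound 1 to compound 3 (0.65 log units; beyond the scatter) and also goes with weaker inhibition, a step that is larger in its printed size than the bromo step. Each of the two groups therefore raises the number when it is added to a ring that already carries the other, and having both on one ring gives the highest number of the three compounds, so the lower number of the bromo-bearing compound 1 does not carry over once the methoxycarbonyl group is present. Nothing available gives a reason for either step.

The compounds shown leave open whether a chloro or fluoro group on this same carbon would give a step of similar direction and size. They also leave open whether a carboxylic acid or an amide in place of the methoxycarbonyl group would keep the higher number seen with bromo on the ring.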